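The compounds below may be only part of what the source reports. "The series", "measured", "known", "first", "only" and "open" are said of these compounds alone.

In a functional assay on HT-29 cells (Homo sapiens) for inhibition (on this read-out lower numbers stand for stronger inhibition and higher numbers for weaker inhibition), compound 1 `N[C@H]1CC[C@H](Nc2nc(NCc3cccc(I)c3)c3ncn(C4CCCC4)c3n2)CC1` gives 1200 nM and compound 2 `N[C@H]1CC[C@H](Nc2nc(NCC3CC3)c3ncn(C4CCCC4)c3n2)CC1` gives 2000 nM. These two values lie within the scatter of each other, so compound 2 has no clear rank. Compound 3 `C[C@H](Nc1nc(N[C@H]2CC[C@H](N)CC2)nc2c1ncn2C1CCCC1)c1ccccc1` differs from compound 2 as follows: 1-phenylethyl in place of cyclopropylmethyl on a nitrogen on an aromatic ring. In words, this is 1-phenylethyl in place of cyclopropylmethyl on a nitrogen on an aromatic ring. Within the data shown here, the only measured step that changes a group on this nitrogen is a 1.7-fold higher number from compound 1 to compound 2 (0.22 log units; within the scatter), so no change beyond the scatter is expected in this assay. The estimated step is a 1.3-fold lower number from compound 2 to compound 3 (0.12 log units; within the scatter). Compound 3 is expected near 1500 nM, within an estimated range of 500 nM to 4500 nM.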

Compound 3, half-maximal inhibitory concentration: 5700 nM
Estimate against measurement, compound 3: 3.8-fold (0.58 log units) below, and the stated range ends below it.
By their numbers in this assay, from the lowest: compounds 1 and 2 (each within the scatter of the next); then compound 3.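

In this assay this nitrogen proves sensitive to its substituent: 1-phenylethyl gives a 2.9-fold higher number from compound 2 to compound 3 (0.45 log units; beyond the scatter) and, set against 3-iodobenzyl, a 4.8-fold higher number from compound 1 to compound 3 (0.68 log units; beyond the scatter) on the read-out. Compound 1 and compound 3 both carry a six-membered aromatic ring, so having that ring does not by itself set the number. Nothing available explains this shift. Still open, on these data alone, is how much depends on the defined stereocentre of 1-phenylethyl and how much on the iodine of compound 1. A plain benzyl group and the mirror-image 1-phenylethyl group would help separate the two.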